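Shortening the ester chain of an isopropyl cinnamate

The compounds below may be only part of what the source reports. "The series", "measured", "known", "first", "only" and "open" are said of these compounds alone.

Compound 1 `CCCCCNC(=O)/C=C/c1ccccc1`, compound 2 `CCCCCCCCNC(=O)/C=C/c1ccccc1` and compound 3 `CCCCCOC(=O)/C=C/c1ccc(C(C)C)cc1` have been tested in a functional assay on the whole organism for inhibition, with Brassica rapa subsp. chinensis as the target, with a stated time of 3 days, tested at 100 ppm; a lower number here means less inhibition of growth, a higher number more inhibition of growth at the concentration tested. Compound 1 gives 76%, compound 2 gives 42% and compound 3 gives 0%, the lowest of the three. From compound 2 to compound 1 the change is hydrogen in place of propyl on a saturated chain carbon, five bonds along the chain from an amide-type nitrogen, and it made a step of a number 34 percentage points higher from compound 2 to compound 1 (beyond the scatter). Compound 4 `CCOC(=O)/C=C/c1ccc(C(C)C)cc1` is not yet measured; it arises from compound 3 by hydrogen in place of propyl on a saturated chain carbon, two bonds along the chain from an oxygen next to a carbonyl group. This is the same kind of change, but the places differ: in the first the carbon lies five bonds along the chain from an amide-type nitrogen, in the second two bonds along the chain from an oxygen next to a carbonyl group. The difference between the two cores is not broken down here. Since compound 3 gives 0% in this assay, only a modest rise is expected from the same kind of change, a number 15 percentage points higher from compound 3 to compound 4 (beyond the scatter). Compound 4 is estimated at 15%, with a range from 0% to 50%.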

Compound 4, percent growth inhibition at one concentration: 0%
For compound 4 the middle estimate is 15 percentage points above the measured one, within the range that was stated.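

In this assay the shortened ester shows no change at the digits printed from compound 3 to compound 4 (within the scatter), so the change did not carry over with the size it had on the core of compound 2: the same change on two cores in this assay, a number 34 percentage points higher (beyond the scatter) from compound 2 to compound 1 and no change at the digits printed (within the scatter) from compound 3 to compound 4, 34 percentage points apart, beyond the scatter of two such steps The step seen on one core therefore cannot be applied as a fixed amount to the other in this series. This does not show which difference between the two cores separates the steps, and a single pair on each core gives no general rule.

From the compounds shown here alone, it remains open whether a carboxylic acid in place of the ester would give any inhibition on the core of compound 3. The same question stands for a longer chain on that ester.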